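Three Inactive Chalcones and a Chlorohydroxyphenyl Newcomer

The source may hold more compounds than are shown below. What is called first, only, known or untested is meant among the compounds shown, and "the series" means these compounds.

Measured compounds:
compound 1, `COc1ccc(C(=O)/C=C/c2cc(OC)c(OC)c(OC)c2)c2c1C=CC(C)(C)O2`, > 10000 nM
compound 2, `COc1ccc(C(=O)/C=C/c2ccc(C(F)(F)F)cc2)c2c1C=CC(C)(C)O2`, > 10000 nM
compound 3, `COc1ccc(C(=O)/C=C/c2ccco2)c2c1C=CC(C)(C)O2`, > 10000 nM

In a functional assay on K562 cells (Homo sapiens) for antiproliferative activity, read by MTT assay, with a stated time of 24 h (on this read-out higher numbers stand for weaker inhibition and lower numbers for stronger inhibition), compound 1 gives > 10000 nM, which is a limit of the assay and not a number. Compound 2 likewise gives > 10000 nM, again a limit. Compound 3 gives > 10000 nM, also a limit, so nothing separates the three on the numbers shown; all of them sit at the limit of > 10000 nM in this assay, at which 3 of the 3 values shown sit. Among the measured compounds shown here, compound 3 therefore stands at the limit, with no measured step leading from it to any other compound.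

Compound 4, `COc1ccc(C(=O)/C=C/c2cc(Cl)ccc2O)c2c1C=CC(C)(C)O2`, has not yet been measured in this assay. It differs from compound 3 by 5-chloro-2-hydroxyphenyl in place of furan-2-yl on a double-bonded chain carbon bound to a double-bonded chain carbon. For the measured compounds named here, since every measured compound sits at the limit, there is no measured step from which a direction could be read, and nothing in the measured data bears on the change itself. The expected step that the limit leaves unreadable from compound 3 to compound 4 is therefore taken as none beyond the scatter, with the likeliest outcome being another limit. Compound 4 is accordingly estimated at 15000 nM, with a range from 4000 nM to 60000 nM.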

Compound 4, half-maximal inhibitory concentration: 5510 nM
For compound 4 the middle estimate is 2.7-fold (0.43 log units) above the measured one; the measured number falls inside the stated range.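

In this assay compound 4 gives 5510 nM, which shows that this place, on a double-bonded chain carbon bound to a double-bonded chain carbon, can carry a group that yields a number rather than a limit. Putting 5-chloro-2-hydroxyphenyl in place of furan-2-yl gives an at least 1.8-fold lower number from compound 3 to compound 4 (0.25 log units; that floor lies within the scatter), and this figure is only a floor, so the true size of the step cannot be read from it. Compound 4 is the only compound shown with a number, and the others remain limits: the limit of > 10000 nM in this assay, at which 3 of the 4 values shown sit.

The compounds shown leave open whether the chlorine, the hydroxyl or the two together account for the number of compound 4, as none of them carries one of these groups on a phenyl ring without the other. From the compounds shown here alone, it also remains open how an amine in place of that hydroxyl, or a bromine in place of that chlorine, would read in this assay.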